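Removing chloro from compound 2: working notes

A few compounds are considered here, and "the series" means these few. Any claim that something is new, unique, unknown or untested is made for them only; others in the source may bear on it.

- compound 1 `CCC(C)NC(=N)c1ccc(Nc2nc3cc(C(=N)NC(C)CC)ccc3[nH]2)cc1`: 93600 nM
- compound 2 `N=C(N)c1ccc(Nc2nc3cc(Cl)ccc3[nH]2)cc1`: 46400 nM
- compound 3 `CC(C)NC(=N)c1ccc(Nc2nc3cc(C(=N)NC(C)C)ccc3[nH]2)cc1`: 108000 nM

All three values come from an ADME assay on L6 cells (Rattus norvegicus) for cytotoxicity, read by resazurin assay; a higher number here means a weaker inhibitor, a lower number a stronger inhibitor. Compound 2 lies within the scatter of compound 1, and compound 3 has a higher number than compound 2, beyond the scatter.

The next compound is compound 4 `N=C(N)c1ccc(Nc2nc3ccccc3[nH]2)cc1`, which differs from compound 2 as follows: hydrogen in place of chloro on an aromatic carbon. This puts hydrogen in place of chloro on an aromatic carbon. For the measured compounds named here, no pair of measured compounds differs in one place only, so the size of this step has no direct precedent.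

Compound 3, which carries no chloro, gives 108000 nM, though compound 1, also without chloro, stays within the scatter of compound 2 and goes against any clear trend. Only a small move toward a higher number is therefore expected, and it is not expected to clear the scatter: a 1.5-fold higher number from compound 2 to compound 4 (0.18 log units; within the scatter).

For compound 4 the estimated value is 70000 nM, with an expected range of 30000 nM to 160000 nM.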

Compound 4, half-maximal inhibitory concentration: 123000 nM
Compound 4: the middle estimate sits 1.8-fold (0.24 log units) below what was measured; low and high end bracket the measured number.
By their numbers in this assay, from the lowest: compounds 2, 1, 3 and 4 (each within the scatter of the next, the first and the last beyond it).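

In this assay, for the compounds shown here, hydrogen in place of chloro on an aromatic carbon gives a 2.7-fold higher number from compound 2 to compound 4 (0.42 log units; beyond the scatter), the first step that can be read at a single place. This shows that the position is not silent in this assay: with the rest of the structure unchanged, the compound carrying chloro has the lower number, though this rests on a single pair. Nothing measured here explains the size of this step.

Going by these compounds, it remains open whether this step is specific to chloro or would also appear with another group at this position, such as fluoro, methyl or methoxy. On these data alone, it is also open whether removing chloro would have a similar effect in a compound with a different group elsewhere on the shared core.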